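Phenyl to furan-3-yl on the shared core

The source may hold more compounds than are shown below. What is called first, only, known or untested is meant among the compounds shown, and "the series" means these compounds.

Compound 1 `CCCCC#Cc1cc([C@@H]2O[C@H](CO)[C@@H](O)[C@H]2O)n2ncnc(N)c12` carries a hex-1-yn-1-yl group on the shared core, and in a functional assay on HCT-116 cells (Homo sapiens) for antiproliferative activity, with a stated time of 72 h (on this read-out higher numbers stand for weaker inhibition and lower numbers for stronger inhibition), compound 1 gives 2900 nM. Compound 2 `Nc1ncnn2c([C@@H]3O[C@H](CO)[C@@H](O)[C@H]3O)cc(C#Cc3ccc(F)cc3)c12` has 4-fluorophenyl in place of butyl on the triple-bonded carbon. In this assay compound 2 reaches only > 100000 nM, which is the limit of > 100000 nM in this assay, at which 1 of the 3 values shown sits, rather than a measured number. Compound 3 `Nc1ncnn2c([C@@H]3O[C@H](CO)[C@@H](O)[C@H]3O)cc(-c3ccccc3)c12` bears phenyl in place of hex-1-yn-1-yl on the aromatic carbon; in this assay compound 3 gives 82600 nM. The steps run an at least 34-fold higher number from compound 1 to compound 2 (1.53 log units; beyond the scatter) and a 28-fold higher number from compound 1 to compound 3 (1.45 log units; beyond the scatter), so compound 3 stands highest of the two numbers, with compound 1 as its nearest neighbour. Between the two weak compounds the step is an at least 1.2-fold lower number from compound 2 to compound 3 (0.08 log units; that floor lies within the scatter).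

Compound 4 `Nc1ncnn2c([C@@H]3O[C@H](CO)[C@@H](O)[C@H]3O)cc(-c3ccoc3)c12` differs from compound 3 by furan-3-yl in place of phenyl on an aromatic carbon. Among the measured compounds shown here, no measured step exchanges one aromatic ring for another directly on the aromatic carbon; the steps that bear on it are the large losses from compound 1 and the step from compound 2 to compound 3, where phenyl and 2-(4-fluorophenyl)ethynyl sit at the same weak level. A step in this assay of no more than the scatter is therefore expected, in either direction. Compound 4 is expected to give 80000 nM, between 30000 nM and 200000 nM, an expected step of a 1.0-fold lower number from compound 3 to compound 4 (0.01 log units; within the scatter).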

Compound 4, half-maximal inhibitory concentration: 1400 nM
Beside the measured number, compound 4's estimate is 57-fold (1.76 log units) above it; the whole stated range lies above it.
By their numbers in this assay, from the lowest: compound 4; then compound 1; then compound 3. At a limit, above all of these: compound 2.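

Notes on the aromatic carbon two ring bonds from the ring nitrogen: in this assay this position separates sharply between two directly attached aromatic rings, with a 59-fold lower number from compound 3 to compound 4 (1.77 log units; beyond the scatter) as phenyl gives way to furan-3-yl, a change of one six-membered carbon ring for a five-membered ring holding one oxygen and one hydrogen-bond acceptor. The triple bond is also no requirement for the best number here, since a 2.1-fold lower number from compound 1 to compound 4 (0.32 log units; beyond the scatter) with furan-3-yl in place of hex-1-yn-1-yl, which leaves compound 4 as the most potent of the four. Against the 2-(4-fluorophenyl)ethynyl group the step is only a floor, an at least 71-fold lower number from compound 2 to compound 4 (1.85 log units; beyond the scatter), and compound 2 stands at a limit rather than a number: the limit of > 100000 nM in this assay, at which 1 of the 4 values shown sits.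

These four compounds do not settle whether the ring oxygen or the smaller ring lies behind the step from phenyl to furan-3-yl, and furan-2-yl, thiophen-3-yl or pyridin-3-yl on the same aromatic carbon would address that. On these data alone, it also remains open how an added methyl or amine on the furan-3-yl ring would read in this assay.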